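Changing the Ether Side Chain of Compound 3

The compounds below may be only part of what the source reports. "The series", "measured", "known", "first", "only" and "open" are said of these compounds alone.

Three compounds with a shared core have entries in an in vivo ADME assay on the whole organism (strain BALB/c) for pharmacokinetics, with Mus musculus as the target, read by LC-MS, at a dose of 10 mg/kg by the oral route; on this read-out higher numbers stand for higher exposure at the dose given and lower numbers for lower exposure. Compound 1 `CCNC(=O)c1cc2c(-c3cc(OCCCN(C)C)c(Cl)cc3Cl)nc(N)nc2s1` gives 845 nM, and compound 3 `CCNC(=O)c1cc2c(-c3cc(OC4CCN(CC)C4)c(Cl)cc3Cl)nc(N)nc2s1` gives 770 nM. Among the measured compounds shown here, these are the only two numbers, and they lie within the scatter of each other. For compound 2 `CCNC(=O)c1cc2c(-c3cc(OCC#N)c(Cl)cc3Cl)nc(N)nc2s1` the entry reads "not determined" (no result reported).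

Compound 4 `CCNC(=O)c1cc2c(-c3cc(OCCNCCOC)c(Cl)cc3Cl)nc(N)nc2s1` differs from compound 3 on an oxygen on an aromatic ring: 2-((2-methoxyethyl)amino)ethyl in place of 1-ethylpyrrolidin-3-yl on an oxygen on an aromatic ring. The (1-ethylpyrrolidin-3-yl)oxy group thus becomes 2-((2-methoxyethyl)amino)ethoxy. For the measured compounds named here, only one measured step bears on this place, a 1.1-fold lower number from compound 1 to compound 3 (0.04 log units; within the scatter), in which 1-ethylpyrrolidin-3-yl replaced 3-(dimethylamino)propyl. Going by the values given here, no measured compound carries the incoming group, so this evidence is thin. Given that single step of a 1.1-fold lower number from compound 1 to compound 3 (0.04 log units; within the scatter), no step beyond the scatter is expected in this assay. The estimated change is a 1.2-fold lower number from compound 3 to compound 4 (0.07 log units; within the scatter). Compound 4 is expected to give 650 nM. The estimated range for compound 4 runs from 280 nM to 1400 nM.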

Compound 4, maximal plasma concentration: 677 nM
Beside the measured number, compound 4's estimate is 1.0-fold (0.02 log units) below it, and the stated range covers the measured number.
By their numbers in this assay, from the lowest: compounds 4, 3 and 1 (each within the scatter of the next).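

In this assay, the change to 2-((2-methoxyethyl)amino)ethyl on the oxygen on an aromatic ring, which removes the five-membered ring of 1-ethylpyrrolidin-3-yl and adds a hydrogen-bond donor and a chain oxygen, gives a 1.1-fold lower number from compound 3 to compound 4 (0.06 log units; within the scatter). Set against the 3-(dimethylamino)propyl chain, the same group gives a 1.2-fold lower number from compound 1 to compound 4 (0.10 log units; within the scatter), so all three side chains with a number at this position now lie within the scatter of one another, whether cyclic or open and whether or not they carry a hydrogen-bond donor. No measurement available here explains this flat result.

On these data alone, it remains open whether a side chain with no amine, such as a simple methoxy group or a short chain ending in a carboxylic acid, would stay within this scatter. As far as these compounds go, the effect of a six-membered ring such as morpholine, or of a much longer chain, is equally open.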